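A few compounds are considered here, and "the series" means these few. Any claim that something is new, unique, unknown or untested is made for them only; others in the source may bear on it.

Measured compounds:
compound 1, `Clc1ccc(Cn2cc(COc3ccccc3)nn2)cc1`: > 100 ug/mL
compound 2, `Cc1ccc(OCc2cn(Cc3ccc([N+](=O)[O-])cc3)nn2)cc1`: > 100 ug/mL

In an ADME assay on A549 cells (Homo sapiens) for inhibition, read by MTT assay, with a stated time of 48 h (on this read-out lower numbers stand for stronger inhibition of growth and higher numbers for weaker inhibition of growth), compound 1 gives > 100 ug/mL, which is a limit of the assay rather than a number. Compound 2 likewise gives > 100 ug/mL, also only a limit. Both measured values thus sit at the limit of > 100 ug/mL in this assay, at which 2 of the 2 values shown sit. Compound 3, `Cc1ccc(OCc2cn(Cc3ccc(Cl)cc3)nn2)cc1`, has not yet been measured; it differs from compound 2 by chloro in place of nitro on an aromatic carbon. Within the data shown here, no measured pair shows this change, and both measured compounds reached only a limit, so no step beyond the usual scatter is expected in this assay. Compound 3 is therefore estimated at 150 ug/mL (range 60 ug/mL to 400 ug/mL), an expected step that the limit leaves unreadable from compound 2 to compound 3, most likely again reported as a limit.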

Compound 3, concentration for 50% growth inhibition: > 100 ug/mL
Compound 3 was reported as a limit; the forecaster's own chance of this, stated with the estimate: 80%; the middle value lies beyond the limit too.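

Among these compounds, compound 3, like compound 1 and compound 2, gave only a limit, so no step from either compound to compound 3 can be read: the limit of > 100 ug/mL in this assay, at which 3 of the 3 values shown sit.

The compounds shown leave open how strongly each inhibits growth, and whether swapping nitro for chloro or adding methyl changes that at all.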